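From pyridin-2-yl to pyridin-3-yl on the amide

This account rests on a few compounds, and the source may have more. Where it says the series, first, only, none or still open, it means among the compounds named here.

compound 1 `CCCN(CCC)C(=O)Cn1c(-c2ccc(Cl)cc2)nc2cccnc21` gives 11 mg/kg
compound 2 `O=C(Cn1c(-c2ccc(Cl)cc2)nc2cccnc21)N1CCCCC1` gives 56.2 mg/kg
compound 3 `O=C(Cn1c(-c2ccc(Cl)cc2)nc2cccnc21)Nc1ccccn1` gives 100 mg/kg

In a functional assay on the whole organism with Mus musculus as the target (a higher number here means that more compound is needed for the effect, a lower number that less compound is needed), compound 3 stands at 100 mg/kg and sits level with compound 2 within the scatter, as a 1.8-fold higher number from compound 2 to compound 3 (0.25 log units; within the scatter) shows, while a 9.1-fold higher number from compound 1 to compound 3 (0.96 log units; beyond the scatter) sets it apart from compound 1. The change to compound 4 `O=C(Cn1c(-c2ccc(Cl)cc2)nc2cccnc21)Nc1cccnc1` is pyridin-3-yl in place of pyridin-2-yl on an amide-type nitrogen and puts pyridin-3-yl in place of pyridin-2-yl on an amide-type nitrogen. Among the compounds with values here, no measured step swaps one pyridinyl group for another. The nearest evidence lies on the same carbonyl carbon, where a 1.8-fold higher number from compound 2 to compound 3 (0.25 log units; within the scatter) stays small. The modest steps, a 5.1-fold higher number from compound 1 to compound 2 (0.71 log units; beyond the scatter) and a 9.1-fold higher number from compound 1 to compound 3 (0.96 log units; beyond the scatter), both remove dipropylamino, which does not happen here. For compound 4 a step within the scatter and without a firm direction is therefore expected, estimated as a 1.3-fold lower number from compound 3 to compound 4 (0.10 log units; within the scatter) in this assay terms. The estimate for compound 4 is 80 mg/kg with an expected range from 30 mg/kg at the lower end to 200 mg/kg at the upper end.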

Compound 4, dose for half-maximal effect: 100 mg/kg
For compound 4 the middle estimate is 1.3-fold (0.10 log units) below the measured one; low and high end bracket the measured number.
By their numbers in this assay, from the lowest: compound 1; then compounds 2, 3 and 4 (each within the scatter of the next).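

In this assay, the change to pyridin-3-yl in place of pyridin-2-yl on an amide-type nitrogen gives no change at the digits printed from compound 3 to compound 4 (within the scatter) at this position, the first direct view of a swap between the two pyridinyl groups. The other comparisons place compound 4 as compound 3 was placed: a 1.8-fold higher number from compound 2 to compound 4 (0.25 log units; within the scatter) keeps it level with the piperidin-1-yl amide, while a 9.1-fold higher number from compound 1 to compound 4 (0.96 log units; beyond the scatter) leaves it apart from the dipropylamino amide, so the gap to compound 1 holds with either pyridinyl group. The data shown offer no explanation for this result.

Still open, on these data alone, is whether pyridin-4-yl or a plain phenyl on the same nitrogen would read like compound 3 and compound 4. Equally open, as far as these compounds go, is whether butyl chains in place of the propyl chains of compound 1 would retain its lower number.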